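The source may hold more compounds than are shown below. What is called first, only, known or untested is meant among the compounds shown, and "the series" means these compounds.

Series notes. Compound 1 `Cc1ccccc1OS(=O)(=O)c1ccc(N2CCN(C)C2=O)cc1` gives 2900 nM in a functional assay on M21 cells (Homo sapiens) for antiproliferative activity, read by sulforhodamine B assay, with a stated time of 48 h; a higher number here means a weaker inhibitor, a lower number a stronger inhibitor. Compound 2 `CCc1ccccc1OS(=O)(=O)c1ccc(N2CCN(C)C2=O)cc1` gives 2300 nM in this assay, and compound 3 `Cc1cccc(OS(=O)(=O)c2ccc(N3CCN(C)C3=O)cc2)c1` gives 2300 nM. Among the compounds with values here, compound 2 stands level with compound 3 at the digits given; a 1.3-fold lower number from compound 1 to compound 2 (0.10 log units; within the scatter), a 1.3-fold lower number from compound 1 to compound 3 (0.10 log units; within the scatter) and no change at the digits printed from compound 2 to compound 3 (within the scatter) all lie within the scatter, so the numbers so far are flat. Compound 4 `CN1CCN(c2ccc(S(=O)(=O)Oc3cccc(Br)c3)cc2)C1=O` is not yet measured; it differs from compound 2 as follows: 3-bromophenyl in place of 2-ethylphenyl on an oxygen. Within the data shown here, the steps bearing on this are no change at the digits printed from compound 2 to compound 3 (within the scatter) and a 1.3-fold lower number from compound 1 to compound 3 (0.10 log units; within the scatter), both within the scatter, so changing the aryl group on the oxygen has so far moved nothing; no bromine-bearing analogue has been measured. Compound 4 is therefore expected to show no change at the digits printed from compound 2 to compound 4 (within the scatter). The estimate for compound 4 is 2300 nM, with a range from 1100 nM to 4800 nM.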

Compound 4, half-maximal inhibitory concentration: 1300 nM
Estimate against measurement, compound 4: 1.8-fold (0.25 log units) above; low and high end bracket the measured number.
By their numbers in this assay, from the lowest: compounds 4, 2, 3 and 1 (each within the scatter of the next, the first and the last beyond it).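

Within this assay, bromo in place of methyl on an aromatic carbon gives a 1.8-fold lower number from compound 3 to compound 4 (0.25 log units; within the scatter), and the change from the 2-ethylphenyl group gives a 1.8-fold lower number from compound 2 to compound 4 (0.25 log units; within the scatter). Within the data shown here, only the change from the 2-methylphenyl group, with a 2.2-fold lower number from compound 1 to compound 4 (0.35 log units; beyond the scatter), passes the scatter, so the aryl group on the oxygen is the first change to reach a modest difference, though that step alters both substituent and its place on the ring. No measurement at hand explains this step.

The compounds shown do not separate the effect of bromo from that of its place on the ring. On these data alone, how chloro, methoxy, an amine or a carboxylic acid on this aryl group would read remains open.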